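Benzylamine substituent series: the step to compound 4

This account rests on a few compounds, and the source may have more. Where it says the series, first, only, none or still open, it means among the compounds named here.

Measured so far in a functional assay on BE(2)-C cells (Homo sapiens) for inhibition, read by MTT assay, with a stated time of 72 h; on this read-out lower numbers stand for stronger inhibition of growth and higher numbers for weaker inhibition of growth:
- compound 1 `O=S(=O)(NCCCNCc1ccc(C(F)(F)F)cc1)c1cc(C(F)(F)F)cc(C(F)(F)F)c1` gives 2700 nM
- compound 2 `O=S(=O)(NCCCNCc1ccccc1)c1cc(C(F)(F)F)cc(C(F)(F)F)c1` gives 12000 nM
- compound 3 `O=S(=O)(NCCCNCc1ccc(Br)cc1)c1cc(C(F)(F)F)cc(C(F)(F)F)c1` gives 2700 nM

Compound 3 stands level with compound 1 at the digits shown, the two together holding the lowest numbers of the three. The step of no change at the digits printed from compound 1 to compound 3 (within the scatter) is within the scatter, whereas the step of a 4.4-fold lower number from compound 2 to compound 3 (0.65 log units; beyond the scatter) is beyond it, so compound 2 is the furthest of the three from compound 3.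

Compound 4 `O=S(=O)(NCCCNCc1ccc(-c2ccccc2)cc1)c1cc(C(F)(F)F)cc(C(F)(F)F)c1` differs from compound 3 in one place: phenyl in place of bromo on an aromatic carbon. Among the measured compounds shown here, two measured steps bear on this position. The step of a 4.4-fold higher number from compound 1 to compound 2 (0.65 log units; beyond the scatter) and the step of a 4.4-fold lower number from compound 2 to compound 3 (0.65 log units; beyond the scatter) both show that the bare aromatic carbon goes with the higher number, while the step of no change at the digits printed from compound 1 to compound 3 (within the scatter) shows that exchanging one group for another at this position leaves the number unchanged. Compound 4 keeps a group at that carbon, so the expectation in this assay is a step within the scatter, or at most a modest lowering; a phenyl has not been tested here, so the range is kept wide. For compound 4 the estimate is 2000 nM, between 700 nM and 6000 nM, which is expected to mean a 1.4-fold lower number from compound 3 to compound 4 (0.13 log units; within the scatter).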

Compound 4, concentration for 50% growth inhibition: 2600 nM
The estimate for compound 4 lay 1.3-fold (0.11 log units) below the measured number, and the stated range covers the measured number.
By their numbers in this assay, from the lowest: compounds 4, 1 and 3 (each within the scatter of the next); then compound 2.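

In this assay, the size of the group at this aromatic carbon, para to a large group, makes no difference that can be read across the range shown: phenyl brings six heavy atoms and a six-membered aromatic ring in place of the single heavy atom of bromo, and the result is a 1.0-fold lower number from compound 3 to compound 4 (0.02 log units; within the scatter). The exchange of trifluoromethyl for phenyl reads the same way, a 1.0-fold lower number from compound 1 to compound 4 (0.02 log units; within the scatter), so a group carrying a whole ring now joins bromo and trifluoromethyl at one level. The separation from the unsubstituted compound also extends to this third group, a 4.6-fold lower number from compound 2 to compound 4 (0.66 log units; beyond the scatter), and among the four compounds none goes against the pattern that a group at this carbon gives a lower number than hydrogen.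

Still open, on these data alone, is how an amine, a carboxylic acid or a methoxy group at this carbon would read, and whether a ring larger than phenyl would stay at the same level. No measurement is available that explains why these three different groups give such similar numbers.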